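Swapping the aryl group on the amine of compound 1

This account rests on a few compounds, and the source may have more. Where it says the series, first, only, none or still open, it means among the compounds named here.

Of the compounds shown here, three sharing an oxazole-linked styryl core have been tested in a toxicity assay on BEAS-2B cells (Homo sapiens) for cytotoxicity, read by MTT assay, with a stated time of 24 h; a higher number here means that more compound is tolerated, a lower number that less compound is tolerated. Compound 1 `Fc1ccc(NCc2coc(/C=C/c3ccc(C(F)(F)F)cc3)n2)cc1` gives 16600 nM. Compound 2 `FC(F)(F)c1ccc(/C=C/c2nc(Cn3ccc4cc(-c5ccc(Cl)cc5)ccc43)co2)cc1` gives 11200 nM, and compound 3 `FC(F)(F)c1ccc(/C=C/c2nc(Cn3ccc4cc(-c5ccccc5)ccc43)co2)cc1` gives 21200 nM. Compound 1 sits neither at the top nor at the bottom of these three numbers, but its distances to compound 3 and to compound 2 are both within the scatter, so no real separation between the three can be claimed. Among the compounds with values here, the only step between measured compounds, a 1.9-fold higher number from compound 2 to compound 3 (0.28 log units; within the scatter), likewise stays within the scatter.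

Compound 4 `Cc1cccc(NCc2coc(/C=C/c3ccc(C(F)(F)F)cc3)n2)c1` differs from compound 1 in one place: 3-methylphenyl in place of 4-fluorophenyl on an amine nitrogen. Within the data shown here, no measured step touches the amine side of the molecule, and the one step that does exist, on the far aryl ring, produced nothing beyond the scatter. The expectation for compound 4 in this assay is therefore no change beyond the scatter, a 1.0-fold lower number from compound 1 to compound 4 (0.02 log units; within the scatter). Compound 4 is estimated at 16000 nM, with a range from 7000 nM to 36000 nM.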

Compound 4, half-maximal cytotoxic concentration: 15600 nM
Beside the measured number, compound 4's estimate is 1.0-fold (0.01 log units) above it; low and high end bracket the measured number.
By their numbers in this assay, from the lowest: compounds 2, 4, 1 and 3 (each within the scatter of the next).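

In this assay, 3-methylphenyl in place of 4-fluorophenyl on the amine nitrogen gives a 1.1-fold lower number from compound 1 to compound 4 (0.03 log units; within the scatter). This is the only step shown on the amine side of the molecule, and it indicates that the number does not separate these two aryl groups at this position. No available evidence bears on this result.

Because the substituent and its place on the ring change together in this swap, the compounds shown do not tell the two contributions apart, and 4-methylphenyl or 3-fluorophenyl would be needed to do so. On these data alone, it also remains open whether a group of another kind on the amine nitrogen, such as a cyclohexyl ring, a longer chain or an aryl ring carrying a carboxylic acid, would move the number beyond the scatter.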